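Removing one methoxy group from a pyrazole chalcone

The source may report more compounds than this note shows. Statements on the series, on what has been measured and on what is new or still open speak of the compounds shown alone.

Compound 1 `COc1cc(-c2cc(/C=C/C(=O)c3ccc(N)cc3)[nH]n2)cc(OC)c1OC` was tested in a functional assay on ACHN cells (Homo sapiens) for cytotoxicity, read by sulforhodamine B assay, with a stated time of 48 h, tested at 1 uM (a lower number here means a stronger effect, a higher number a weaker effect of the compound at the concentration tested), and gave 79%. Compound 2 `COc1ccc(C(=O)/C=C/c2cc(-c3cc(OC)c(OC)c(OC)c3)n[nH]2)cc1OC` gave 91%, and compound 3 `COc1ccc(C(=O)/C=C/c2cc(-c3cc(OC)c(OC)c(OC)c3)n[nH]2)cc1` gave 105%. The cores of compound 1 and compound 2 differ by 4-aminophenyl in place of 3,4-dimethoxyphenyl on a carbonyl carbon, a change that gave a number 12 percentage points higher from compound 1 to compound 2 (beyond the scatter). Within the core of compound 2, the change hydrogen in place of methoxy on an aromatic carbon gave a number 14 percentage points higher from compound 2 to compound 3 (beyond the scatter), so the effect weakened. Compound 4 `COc1ccc(-c2cc(/C=C/C(=O)c3ccc(N)cc3)[nH]n2)cc1OC` is not yet measured; it differs from compound 1 by hydrogen in place of methoxy on an aromatic carbon, the same kind of change, but here the place is also meta to a methoxy group. Compound 4 is expected to show a number 13 percentage points higher from compound 1 to compound 4 (beyond the scatter), resting on the step from compound 2 to compound 3 a number 14 percentage points higher from compound 2 to compound 3 (beyond the scatter), so an estimate of 92% is expected, within 78% and 106%.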

Compound 4, a percentage reported as activity, at one concentration (the size of the read-out at that concentration, not a potency): 88%
For compound 4 the middle estimate is 4 percentage points above the measured one; the measured number falls inside the stated range.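

In this assay, hydrogen in place of methoxy on the core of compound 1 gave a number 9 percentage points higher from compound 1 to compound 4 (within the scatter) and so cannot be told apart from no change at all. Set beside the earlier case, the two steps agree as far as the scatter can tell: the same change on two cores in this assay, a number 14 percentage points higher (beyond the scatter) from compound 2 to compound 3 and a number 9 percentage points higher (within the scatter) from compound 1 to compound 4, 5 percentage points apart, within the scatter of two such steps. This shows that the change gave no detectable difference in step size between these two cores, but two pairs cannot show that it would carry over in the same way to any other core in the series.

The compounds shown leave open whether a hydroxyl or an ethoxy group in that place would behave like methoxy or like hydrogen. As far as these compounds go, each read-out also comes from a single concentration, so it tells only whether the effect is stronger or weaker at that concentration, and how this change would act at other concentrations remains unknown.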